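Swapping cyclohexyl for 3,4-difluorophenyl on the carbonyl

The source may hold more compounds than are shown below. What is called first, only, known or untested is meant among the compounds shown, and "the series" means these compounds.

Three measured compounds share one core and differ only in the group on a carbonyl carbon. Compound 1 `CC(C)OC(=O)C1=CN(C(=O)c2ccc(C#N)cc2)CC(C)(C)c2cc(C#N)[nH]c21` carries 4-cyanophenyl there, and in an assay on HEK293 cells for agonist activity at Bile acid receptor (Homo sapiens), read by a luciferase reporter (a higher number here means that more compound is needed for the effect, a lower number that less compound is needed), compound 1 gives 35 nM. Compound 2 `CC(C)OC(=O)C1=CN(C(=O)c2cccs2)CC(C)(C)c2cc(C#N)[nH]c21` carries thiophen-2-yl, and in this assay compound 2 gives 16 nM. Compound 3 `CC(C)OC(=O)C1=CN(C(=O)C2CCCCC2)CC(C)(C)c2cc(C#N)[nH]c21` carries cyclohexyl, and in this assay compound 3 gives 6.5 nM, the lowest of the three numbers. All steps point the same way: a 2.2-fold lower number from compound 1 to compound 2 (0.34 log units; beyond the scatter), a 5.4-fold lower number from compound 1 to compound 3 (0.73 log units; beyond the scatter) and a 2.5-fold lower number from compound 2 to compound 3 (0.39 log units; beyond the scatter). Among these three, the non-aromatic ring gives the lowest number and each aromatic ring a higher one.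

Compound 4 `CC(C)OC(=O)C1=CN(C(=O)c2ccc(F)c(F)c2)CC(C)(C)c2cc(C#N)[nH]c21` is not yet measured. Its difference from compound 3 is 3,4-difluorophenyl in place of cyclohexyl on a carbonyl carbon. Among the compounds with values here, the steps that bear on this change are the two that exchange an aromatic ring for cyclohexyl, a 5.4-fold lower number from compound 1 to compound 3 (0.73 log units; beyond the scatter) and a 2.5-fold lower number from compound 2 to compound 3 (0.39 log units; beyond the scatter). Compound 4 runs that exchange backwards, returning to an aromatic ring, though one bearing fluorines, for which no comparison exists among the measured compounds. A rise beyond the scatter is therefore expected, roughly between those two step sizes; the expected step is a 3.1-fold higher number from compound 3 to compound 4 (0.49 log units; beyond the scatter). In this assay compound 4 is expected to give about 20 nM, within a range from 8 nM to 55 nM.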

Compound 4, half-maximal effective concentration: 6.3 nM
Beside the measured number, compound 4's estimate is 3.2-fold (0.50 log units) above it, and the stated range ends above it.
By their numbers in this assay, from the lowest: compounds 4 and 3 (each within the scatter of the next); then compound 2; then compound 1.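

In this assay the exchange on the carbonyl carbon gives a 1.0-fold lower number from compound 3 to compound 4 (0.01 log units; within the scatter) and so leaves the number where it was, which means that an aromatic ring at this position does not by itself go with a higher number. Compound 4 therefore goes against the pattern seen among the three earlier compounds, where cyclohexyl alone gave the lowest number. The choice of aromatic ring now matters, as 3,4-difluorophenyl gives a 2.5-fold lower number from compound 2 to compound 4 (0.40 log units; beyond the scatter) when it replaces thiophen-2-yl and a 5.6-fold lower number from compound 1 to compound 4 (0.74 log units; beyond the scatter) when it replaces 4-cyanophenyl. No measurement at hand explains why this ring behaves differently from the other two aromatic rings.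

The compounds shown leave open whether both fluorines are needed, since plain phenyl, 3-fluorophenyl and 4-fluorophenyl do not appear among them. They also do not say how this position would respond to an open chain such as tert-butyl or to a ring carrying an amine, such as a piperidine.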